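Methyl in place of hydrogen: compound 3 to compound 4

The compounds below may be only part of what the source reports. "The series", "measured", "known", "first", "only" and "open" are said of these compounds alone.

Compound 1 `COc1ccc(-c2nc3cc(F)ccc3s2)cc1`: 490 nM
Compound 2 `COc1ccc(-c2nc3cc(F)ccc3s2)cc1F`: 870 nM
Compound 3 `Oc1ccc(-c2nc3cc(F)ccc3s2)cc1O`: 720 nM

All three numbers come from a functional assay on MCF7 cells (Homo sapiens) for antiproliferative activity; a higher number here means a weaker inhibitor of growth, a lower number a stronger inhibitor of growth. Compound 3 sits second highest of the three, nearest to compound 2 and furthest from compound 1, with both gaps within the scatter. For the measured compounds named here, the only step between measured compounds, a 1.8-fold higher number from compound 1 to compound 2 (0.25 log units; within the scatter), concerns fluoro in place of hydrogen on an aromatic carbon and so does not bear on the change at hand. Compound 4 `COc1ccc(-c2nc3cc(F)ccc3s2)cc1O` differs from compound 3 by methyl in place of hydrogen on an oxygen on an aromatic ring. Going by the values given here, no measured pair shows this change, so no step beyond the scatter is expected in this assay, and the estimate for compound 4 is 650 nM, within 250 nM to 1700 nM. The expected step is a 1.1-fold lower number from compound 3 to compound 4 (0.04 log units; within the scatter).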

Compound 4, concentration for 50% growth inhibition: 500 nM
Estimate against measurement, compound 4: 1.3-fold (0.11 log units) above; low and high end bracket the measured number.
By their numbers in this assay, from the lowest: compounds 1, 4, 3 and 2 (each within the scatter of the next).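

In this assay, methyl in place of hydrogen on an oxygen on an aromatic ring gives a 1.4-fold lower number from compound 3 to compound 4 (0.16 log units; within the scatter), so this hydroxy to methoxy change cannot be told from the scatter. On an aromatic carbon, hydroxy in place of fluoro gives a 1.7-fold lower number from compound 2 to compound 4 (0.24 log units; within the scatter), and hydroxy in place of hydrogen gives a 1.0-fold higher number from compound 1 to compound 4 (0.01 log units; within the scatter), so neither exchange separates these compounds either. No measurement at hand offers an explanation for these readings. From the compounds shown here alone, what a longer chain on this oxygen, or an amine in place of the hydroxy group, would do in this assay stays open.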